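Compound 4: the stereocentre of compound 1 left undrawn

This account rests on a few compounds, and the source may have more. Where it says the series, first, only, none or still open, it means among the compounds named here.

Compound 1 `Cc1ccnc(N2C(=O)CS[C@@H]2c2cccc(C(=O)NCCCCn3cccn3)c2)c1` gives 21.9 nM in a functional assay on HOS-TE85 cells (Homo sapiens) for inhibition, read by CCK-8 assay, with a stated time of 72 h; on this read-out higher numbers stand for weaker inhibition and lower numbers for stronger inhibition
Compound 2 `CC(C)(C)c1conc1N1C(=O)CSC1c1cccc(C(=O)NCCCCc2ccccc2)c1` gives > 1000 nM as a limit
Compound 3 `C#Cc1cc(C(=O)NCCCCc2ccccc2)cc(C2SCC(=O)N2c2ccccc2OC)c1` gives 40.8 nM in the same test

For the measured compounds named here, compound 1 and compound 3 lie within the scatter of each other, and they hold the only exact numbers, since compound 2 is reported only as a limit. Compound 4 `Cc1ccnc(N2C(=O)CSC2c2cccc(C(=O)NCCCCn3cccn3)c2)c1` is the next to be read, and it relates to compound 1 as follows: the two compounds have the same atoms and bonds; at least one stereo element is drawn with a configuration in one of them and without one in the other: 1 of 1 stereo elements differ; a stereocentre at a saturated ring carbon is drawn R in compound 1 and without a configuration in compound 4. Going by the values given here, no measured pair shows what such a change does in this assay, so only a small rise in the number is expected, within the scatter. The expected step is a 1.5-fold higher number from compound 1 to compound 4 (0.18 log units; within the scatter) and rests on compound 1 at 21.9 nM alone. Compound 4 is estimated at 33 nM, with an expected range from 14 nM to 90 nM.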

Compound 4, half-maximal inhibitory concentration: 19.6 nM
Compound 4: middle estimate off by 1.7-fold (0.23 log units), on the high side; the range from low to high includes it.
By their numbers in this assay, from the lowest: compounds 4, 1 and 3 (each within the scatter of the next, the first and the last beyond it). At a limit, above all of these: compound 2.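

In this assay, leaving the configuration at the saturated ring carbon undrawn gives a 1.1-fold lower number from compound 1 to compound 4 (0.05 log units; within the scatter), a step within the scatter. For the compounds shown here, this is the first pair in the set to differ at this stereocentre alone, and the two values cannot be told apart. The comparison concerns only how this one centre is specified: the fact that one of compounds 1 and 4 is drawn with a defined configuration and the other without, at the place where they differ

Going by these compounds, how a compound drawn S at this carbon would read stays open. So does the effect of a longer chain or an added amine on the chain of compound 1.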